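Larger Nitrogen Substituent and Macrophage Tolerance

The source may report more compounds than this note shows. Statements on the series, on what has been measured and on what is new or still open speak of the compounds shown alone.

Two compounds sharing one core have been examined in an ADME assay on RAW264.7 cells (Mus musculus) for cytotoxicity, read by resazurin assay, with a stated time of 48 h; a lower number here means that less compound is tolerated, a higher number that more compound is tolerated. Compound 1 `CC1=CC(=O)/C(=C(/C)Nc2ccc3cnn(Cc4ccc(C)cc4)c3c2)C(=O)O1` carries a 4-methylbenzyl group on the aromatic nitrogen and no chlorine. In this assay compound 1 gives > 100000 nM, which is a limit of the assay. Compound 2 `CCn1nc(Cl)c2ccc(N/C(C)=C3\C(=O)C=C(C)OC3=O)cc21` carries an ethyl on that nitrogen and a chlorine on the core. In this assay, going by the values given here, compound 2 gives 6230 nM, the only number obtained so far, so its standing can be set only against (the limit of > 100000 nM in this assay, at which 1 of the 2 values shown sits).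

Compound 3 `CC1=CC(=O)/C(=C(/C)Nc2ccc3c(Cl)nn(Cc4ccc(C)cc4)c3c2)C(=O)O1` keeps the chlorine of compound 2 and differs from it by 4-methylphenyl in place of methyl on a saturated chain carbon bound to an aromatic nitrogen; cut one bond further out, this reads ethyl to 4-methylbenzyl. Among the compounds with values here, no measured pair shows this change. Compound 3 thus combines the nitrogen substituent of compound 1 with the chlorine of compound 2. The step is expected to run toward a more tolerated compound, a 6.4-fold higher number from compound 2 to compound 3 (0.81 log units; beyond the scatter). Compound 3 is accordingly expected to show about 40000 nM in this assay, within 10000 nM to 150000 nM, with a fair chance that only a limit is returned.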

Compound 3, half-maximal cytotoxic concentration: > 100000 nM
Compound 3 ended at the assay's limit; the forecaster's own chance of this, stated with the estimate: 40%; middle value at least 2.5-fold (0.39 log units) from the limit.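

In this assay, 4-methylphenyl in place of methyl on a saturated chain carbon bound to an aromatic nitrogen now has a readable size with the chlorine held constant: an at least 16-fold higher number from compound 2 to compound 3 (1.20 log units; beyond the scatter). Compound 1 and compound 2 differ in two places, so they could not assign the gap between them to either change, whereas compound 2 and compound 3 differ in this one place alone. The chlorine, by contrast, stays unresolved with 4-methylbenzyl on the nitrogen, and the step between compound 1 and compound 3, chloro in place of hydrogen on an aromatic carbon, cannot be read: the limit of > 100000 nM in this assay, at which 2 of the 3 values shown sit.

Going by these compounds, it remains open whether the gain depends on the 4-methylphenyl group as such, or whether a plain phenyl, a cyclohexyl or a longer alkyl chain in the same place would also reach the limit. On these data alone, how the chlorine acts with ethyl on the nitrogen is also open, and so is whether a carboxylic acid or an amine on the 4-methylphenyl ring would bring the value back within the readable range.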